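The source may report more compounds than this note shows. Statements on the series, on what has been measured and on what is new or still open speak of the compounds shown alone.

Measured compounds: compound 1 `CC(=O)O[C@@H](C)/C=C\C(=O)N[C@@H]1C[C@H](C)[C@H](C/C=C(C)/C=C/[C@@H]2C[C@]3(CO3)C[C@@H](CC(=O)O)O2)O[C@@H]1C` gives 0.077; compound 2 `CC(=O)O[C@@H](C)/C=C\C(=O)N[C@@H]1C[C@H](C)[C@H](C/C=C(C)/C=C/[C@H]2O[C@H](CC(=O)O)C[C@@]3(CO3)[C@@H]2O)O[C@@H]1C` gives -0.658; compound 3 `COC(=O)C[C@@H]1C[C@@]2(CO2)[C@H](O)[C@@H](/C=C/C(C)=C/C[C@@H]2O[C@H](C)[C@H](NC(=O)/C=C\[C@H](C)OC(C)=O)C[C@@H]2C)O1` gives 2.23.

In a physicochemical assay for lipophilicity, using the shake flask method, measured as octanol-water partition, at pH 7.4 (on this read-out lower numbers stand for lower lipophilicity and higher numbers for higher lipophilicity), compound 1 stands second highest of the three. Its nearest neighbour is compound 2, reached by the step of a number 0.74 log units lower from compound 1 to compound 2 (beyond the scatter). Compound 3 lies furthest away, its value standing well above that of compound 1.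

The unmeasured compound 4 `CCCNC(=O)C[C@@H]1C[C@@]2(CO2)C[C@@H](/C=C/C(C)=C/C[C@@H]2O[C@H](C)[C@H](NC(=O)/C=C\[C@H](C)OC(C)=O)C[C@@H]2C)O1` differs from compound 1 by propylamino in place of hydroxy on a carbonyl carbon. Among the compounds with values here, no measured step makes exactly this change. The step that bears on it most is a number 2.89 log units higher from compound 2 to compound 3 (beyond the scatter), which also replaces the acidic hydrogen of the carboxy group and is large. The step of a number 0.74 log units lower from compound 1 to compound 2 (beyond the scatter) concerns a different position and says less here. Within the data shown here, compound 4 is therefore expected to move upward by a large step, a number 2.72 log units higher from compound 1 to compound 4 (beyond the scatter), with the exact size uncertain because the only comparable step, a number 2.89 log units higher from compound 2 to compound 3 (beyond the scatter), installs a methyl ester rather than a propyl amide. The estimate for compound 4 in this assay is 2.8, within the range 1.8 to 3.8.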

Compound 4, distribution coefficient: 3.72
For compound 4 the middle estimate is 0.92 log units below the measured one, and the stated range covers the measured number.
By their numbers in this assay, from the lowest: compound 2; then compound 1; then compound 3; then compound 4.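

In this assay the carbonyl carbon of the carboxymethyl side chain proves to be a position where a single change moves the read-out strongly: propylamino in place of hydroxy gives a number 3.64 log units higher from compound 1 to compound 4 (beyond the scatter). Within the data shown here, until now this group had been altered only by the methyl ester, in a number 2.89 log units higher from compound 2 to compound 3 (beyond the scatter), and on a parent carrying an extra hydroxy, so compound 4 is the first result showing a large rise on the core of compound 1 itself, and with an amide rather than an ester. No measurement shown here accounts for the size of this step.

The compounds shown leave open how methylamino, butylamino or a propyl chain ending in an amine would read at this carbonyl carbon. They also leave open how propylamino would read on the core of compound 2.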